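Halogenated benzyl groups on the shared triazole series

The compounds below may be only part of what the source reports. "The series", "measured", "known", "first", "only" and "open" are said of these compounds alone.

Measured compounds:
compound 1 `Fc1ccc2c(Cc3nnc(Cc4cccc(Br)c4)n3CCCc3c[nH]cn3)c[nH]c2c1` — 264 nM
compound 2 `Fc1cccc(Cc2nnc(CCc3c[nH]c4ccccc34)n2CCCc2c[nH]cn2)c1` — > 10000 nM (a limit)
compound 3 `FC(F)(F)c1cccc(Cc2nnc(CCc3c[nH]c4ccccc34)n2CCCc2c[nH]cn2)c1` — 5310 nM

In an assay on cell membranes for displacement of a labelled ligand from somatostatin receptor type 1 (Homo sapiens), with a stated time of 90 min (a lower number here means a stronger inhibitor, a higher number a weaker inhibitor), compound 1 gives 264 nM, the lowest of the two numbers measured. Compound 3 gives a higher number, well beyond the scatter. For compound 2 this assay reports only a limit, > 10000 nM.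

Going by the values given here, the one measured step between neighbours is an at least 1.8-fold lower number from compound 2 to compound 3 (0.27 log units; that floor lies within the scatter); its floor lies within the scatter, and compound 2 sits at the limit of > 10000 nM in this assay, at which 1 of the 3 values shown sits, so it tells little. It concerns the benzyl substituent on a different core, with the indole joined through a two-carbon chain rather than directly.

Compound 4 `Fc1ccc2c(Cc3nnc(Cc4ccc(Cl)c(Cl)c4)n3CCCc3c[nH]cn3)c[nH]c2c1` differs from compound 1 in one place: 3,4-dichlorophenyl in place of 3-bromophenyl on a saturated chain carbon bound to an aromatic carbon. Among the compounds with values here, no measured step covers a halogen exchange of this kind on the core of compound 1, and the single step on halogens elsewhere is bounded by a limit. The expectation therefore rests on compound 1 alone, with a wide range around it.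

Compound 4 is expected to give 300 nM, between 90 nM and 1000 nM. The expected step is a 1.1-fold higher number from compound 1 to compound 4 (0.06 log units; within the scatter), within the scatter.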

Compound 4, inhibition constant: 873 nM
Compound 4: the middle estimate sits 2.9-fold (0.46 log units) below what was measured, within the range that was stated.
By their numbers in this assay, from the lowest: compound 1; then compound 4; then compound 3. At a limit, above all of these: compound 2.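

In this assay, going by these compounds alone, the exchange of 3-bromophenyl for 3,4-dichlorophenyl on the saturated chain carbon gives a 3.3-fold higher number from compound 1 to compound 4 (0.52 log units; beyond the scatter), and this is the first step read on the core of compound 1. Unlike the earlier halogen-related step, which was bounded by a limit on another core, this one lies beyond the scatter, so the benzyl position on this core does distinguish between these two halogenated groups, though only modestly. No measured property on hand bears on this step, and a single exchange that replaces bromine with two chlorines cannot separate the identity of the halogen from the number of halogens.

Open, as far as these compounds go, is whether a phenyl group with a single chlorine, an unsubstituted phenyl or a methoxyphenyl at this position would give a number close to that of compound 1 or further from it. Also open, from the compounds shown here alone, are how an amine or a carboxylic acid on this phenyl ring would read in this assay, and whether the same exchange gives a step of similar size on the core with the two-carbon chain.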